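This account rests on a few compounds, and the source may have more. Where it says the series, first, only, none or still open, it means among the compounds named here.

Measured compounds:
Compound 1 `COc1ccc(/C=C2\CN(Cc3cn(Cc4ccc(F)cc4)nn3)C/C(=C\c3ccc(OC)cc3)C2=O)cc1`: 49300 nM
Compound 2 `O=C1/C(=C/c2ccccc2F)CN(Cc2cn(Cc3ccccc3Cl)nn2)C/C1=C\c1ccccc1F`: 5300 nM
Compound 3 `COc1ccc(/C=C2\CN(Cc3cn(Cc4ccccc4Cl)nn3)C/C(=C\c3ccc(OC)cc3)C2=O)cc1`: 11400 nM

Of the compounds shown here, three have been tested in a functional assay on 4T1 cells (Mus musculus) for cytotoxicity, read by MTT assay, with a stated time of 24 h; on this read-out lower numbers stand for stronger inhibition and higher numbers for weaker inhibition. Compound 2 gives the lowest number of the three; compound 3 stands nearest, and compound 1 furthest from it. The difference between the core of compound 2 and the core of compound 3 is not broken down here.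

Compounds 3 and 1 share a core and differ in one place: 4-fluorophenyl in place of 2-chlorophenyl on a saturated chain carbon bound to an aromatic nitrogen. That change made a 4.3-fold higher number from compound 3 to compound 1 (0.64 log units; beyond the scatter).

Compound 4 `O=C1/C(=C/c2ccccc2F)CN(Cc2cn(Cc3ccc(F)cc3)nn2)C/C1=C\c1ccccc1F` is not yet measured. It stands to compound 2 as compound 1 stands to compound 3: 4-fluorophenyl in place of 2-chlorophenyl on a saturated chain carbon bound to an aromatic nitrogen. The place is the same in both pairs, so this is the same change on a different core.

Among the compounds with values here, with only one precedent, a step of similar direction is expected from compound 2 to compound 4 in this assay, estimated at a 3.4-fold higher number from compound 2 to compound 4 (0.53 log units; beyond the scatter), resting on the step from compound 3 to compound 1 and on the value of compound 2, 5300 nM. Compound 4 is therefore expected to give about 18000 nM in this assay, estimated to lie between 7000 nM and 50000 nM.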

Compound 4, half-maximal inhibitory concentration: 6400 nM
Beside the measured number, compound 4's estimate is 2.8-fold (0.45 log units) above it; the whole stated range lies above it.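

In this assay, putting 4-fluorophenyl in place of 2-chlorophenyl made a 1.2-fold higher number from compound 2 to compound 4 (0.08 log units; within the scatter), so on this core the exchange leaves the number within the usual scatter. The same exchange therefore did not carry over in size from one core to the other: the same change on two cores in this assay, a 4.3-fold higher number (0.64 log units; beyond the scatter) from compound 3 to compound 1 and a 1.2-fold higher number (0.08 log units; within the scatter) from compound 2 to compound 4, 3.6-fold (0.55 log units) apart, beyond the scatter of two such steps. This shows that, in these two pairs, the size of the step depends on the core that carries it, but it does not show which feature of the two cores matters, and two pairs give no rule for any further core.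

The exchange alters both the halogen and its place on the ring, so the compounds shown leave open how much of the step from compound 3 to compound 1 belongs to each, which a 4-chlorophenyl or 2-fluorophenyl group could separate. They also leave open how an unsubstituted phenyl group, or an amine or a carboxylic acid in the same place, would read on either core.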